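Swapping the ring on the amide nitrogen for a fluorophenyl

The source may report more compounds than this note shows. Statements on the series, on what has been measured and on what is new or still open speak of the compounds shown alone.

Measured so far:
Compound 1, `O=C(NCCCCc1ccccc1)c1cccc(C2SCC(=O)N2c2ccc(-c3ccccc3)cc2)c1`, in a functional assay on HOS-TE85 cells (Homo sapiens) for inhibition, read by CCK-8 assay, with a stated time of 72 h (on this read-out lower numbers stand for stronger inhibition and higher numbers for weaker inhibition), gives > 1000 nM, which is a limit of the assay rather than a number.
Compound 2, `O=C(NCCCCc1ccccc1)c1cccc(C2SCC(=O)N2c2ccccc2)c1`, gives 15.9 nM.
Compound 3, `COc1ccc(F)cc1N1C(=O)CSC1c1cccc(C(=O)NCCCCc2ccccc2)c1`, gives 8.8 nM.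

Compound 3 has the lowest of the two numbers, but its nearest neighbour, compound 2, sits within the scatter of it, so neither can be called the more potent. Compound 1 only contributes the limit (the limit of > 1000 nM in this assay, at which 1 of the 3 values shown sits).

The next compound, compound 4, `O=C(NCCCCc1ccccc1)c1cccc(C2SCC(=O)N2c2ccccc2F)c1`, keeps the shared core and changes only the ring on the amide-type nitrogen: 2-fluorophenyl in place of 5-fluoro-2-methoxyphenyl on an amide-type nitrogen in a ring.

Two measured steps speak to this change. Removing the phenyl substituent from that ring gave an at least 62-fold lower number from compound 1 to compound 2 (1.79 log units; beyond the scatter), showing that a large substituent there is not tolerated, and going on to the 5-fluoro-2-methoxyphenyl gave a 1.8-fold lower number from compound 2 to compound 3 (0.26 log units; within the scatter), so small substituents on that ring leave the number essentially unchanged. A 2-fluorophenyl is another small substituent of this kind, so compound 4 is expected to stay close to compound 3, with a 1.4-fold higher number from compound 3 to compound 4 (0.13 log units; within the scatter) being no more than the scatter.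

Compound 4 is therefore estimated at 12 nM, within 4 nM to 40 nM.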

Compound 4, half-maximal inhibitory concentration: 34.1 nM
Beside the measured number, compound 4's estimate is 2.8-fold (0.45 log units) below it; the measured number falls inside the stated range.
By their numbers in this assay, from the lowest: compounds 3 and 2 (each within the scatter of the next); then compound 4. At a limit, above all of these: compound 1.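

Small substituents on this ring turn out not to be interchangeable: in this assay, the change to 2-fluorophenyl gives a 3.9-fold higher number from compound 3 to compound 4 (0.59 log units; beyond the scatter), a modest step but one beyond the scatter. Adding a single fluoro to the plain phenyl ring also moves the number, with a 2.1-fold higher number from compound 2 to compound 4 (0.33 log units; beyond the scatter), so here fluoro in place of hydrogen is not neutral, although compound 3, which carries a fluoro together with a methoxy, stays within the scatter of compound 2. Even so, the 2-fluorophenyl sits far closer to these two than to the 4-phenylphenyl, with an at least 29-fold lower number from compound 1 to compound 4 (1.46 log units; beyond the scatter), a step that starts from a limit for compound 1 and not from a number: the limit of > 1000 nM in this assay, at which 1 of the 4 values shown sits.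

From the compounds shown here alone, how much of the number of compound 3 comes from its methoxy and how much from its fluoro stays open. The data do not tell what makes the number of compound 4 higher than that of compound 3. Also unanswered is whether a 2-methoxyphenyl, or a ring bearing an amine or a carboxylic acid, would stay close to compound 2 and compound 3.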